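Methoxy Added to a Weak Cytotoxic Core

This account rests on a few compounds, and the source may have more. Where it says the series, first, only, none or still open, it means among the compounds named here.

Compound 1 `COc1ccc(-c2cc(/N=C3/NC(=O)CS3)cs2)cc1` in a functional assay on HCT-116 cells (Homo sapiens) for cytotoxicity, read by MTT assay, with a stated time of 72 h (a lower number here means a stronger inhibitor, a higher number a weaker inhibitor), gives only a limit, not a number: > 50000 nM
Compound 2 `O=C1CS/C(=N\c2csc(-c3ccccc3)c2)N1` in this assay gives only a limit, not a number: > 50000 nM
Compound 3 `O=C1N/C(=N/c2csc(-c3ccc(Cl)cc3)c2)S/C1=C\c1ccccc1` in this assay gives 11200 nM

Compound 2 and compound 1 differ in one place, (methoxy in place of hydrogen on an aromatic carbon). Both sit at the limit of this assay, so the step that the two limits leave unreadable from compound 2 to compound 1 cannot be read; that rests on (the limit of > 50000 nM in this assay, at which 2 of the 3 values shown sit). Compound 3 differs from compound 2 in more than one place, and the difference between the two cores is not broken down here. Compound 3 is the only one of the three with a number in this assay.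

Compound 4 `COc1ccc(/C=C2\S/C(=N\c3csc(-c4ccc(Cl)cc4)c3)NC2=O)cc1` is not yet measured. It differs from compound 3 by methoxy in place of hydrogen on an aromatic carbon, the same change as from compound 2 to compound 1. Since the earlier step is unreadable, no measured size is available to guide the expectation. The step of a 1.1-fold lower number from compound 3 to compound 4 (0.05 log units; within the scatter) is therefore expected to stay within the usual scatter. For compound 4 in this assay a value near 10000 nM is estimated, in the range 4000 nM to 30000 nM.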

Compound 4, half-maximal inhibitory concentration: 1300 nM
Estimate against measurement, compound 4: 7.7-fold (0.89 log units) above; measured number below the stated range.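

Going from phenyl to 4-methoxyphenyl on the core of compound 3 gives an 8.6-fold lower number from compound 3 to compound 4 (0.94 log units; beyond the scatter) in this assay. This is one pair on one core, so it shows that the change can matter here, but not that methoxy lowers the number wherever it is placed, and it does not tell why the number fell. The same change on the other core, from compound 2 to compound 1, cannot be read, so no comparison between the two cores is possible, because both of those compounds give only a limit and not a number: the limit of > 50000 nM in this assay, at which 2 of the 4 values shown sit.

The compounds shown leave open whether another group in the same place, such as an amine, a carboxylic acid or a longer chain like butoxy, would give a step of similar size on the core of compound 3. Also open, on these data alone, is whether the step depends on the chlorine that compound 3 and compound 4 both carry.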